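This account rests on a few compounds, and the source may have more. Where it says the series, first, only, none or still open, it means among the compounds named here.

Three compounds share one core and differ only in a fluorinated phenyl group on an oxygen on a saturated carbon. Compound 1 `CC(C)[C@H](NC(=O)COc1cccc2ccccc12)C(=O)N[C@@H](CC(=O)O)C(=O)COc1ccc(F)cc1F` gives 33200 nM in a functional assay on Jurkat cells (Homo sapiens); on this read-out lower numbers stand for stronger inhibition and higher numbers for weaker inhibition. Compound 2 `CC(C)[C@H](NC(=O)COc1cccc2ccccc12)C(=O)N[C@@H](CC(=O)O)C(=O)COc1cc(F)c(F)cc1F` carries the change (fluoro in place of hydrogen on an aromatic carbon), and in this assay compound 2 gives 39300 nM, a step of a 1.2-fold higher number from compound 1 to compound 2 (0.07 log units; within the scatter). Compound 3 `CC(C)[C@H](NC(=O)COc1cccc2ccccc12)C(=O)N[C@@H](CC(=O)O)C(=O)COc1c(F)c(F)cc(F)c1F` differs from compound 1 by 2,3,5,6-tetrafluorophenyl in place of 2,4-difluorophenyl on an oxygen on a saturated carbon, and compound 3 gives 4500 nM, a step of a 7.4-fold lower number from compound 1 to compound 3 (0.87 log units; beyond the scatter) and, from compound 2, an 8.7-fold lower number from compound 2 to compound 3 (0.94 log units; beyond the scatter). Compound 4 `CC(C)[C@H](NC(=O)COc1cccc2ccccc12)C(=O)N[C@@H](CC(=O)O)C(=O)COc1c(F)c(F)c(F)c(F)c1F` is not yet measured; it differs from compound 3 by fluoro in place of hydrogen on an aromatic carbon. This is the same kind of change as from compound 1 to compound 2, but the surroundings differ: there the fluoro sat ortho to a fluoro group, meta to a large group and para to a fluoro group, whereas here it sits ortho to two fluoro groups, meta to two fluoro groups and para to a large group. Because the earlier step was a 1.2-fold higher number from compound 1 to compound 2 (0.07 log units; within the scatter), only a small step is expected for compound 4, estimated as a 1.3-fold lower number from compound 3 to compound 4 (0.11 log units; within the scatter). Compound 4 is expected to give about 3500 nM, likely between 1500 nM and 9000 nM.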

Compound 4, half-maximal inhibitory concentration: 3050 nM
Beside the measured number, compound 4's estimate is 1.1-fold (0.06 log units) above it; the measured number falls inside the stated range.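

Fluoro in place of hydrogen on an aromatic carbon gives a 1.5-fold lower number from compound 3 to compound 4 (0.17 log units; within the scatter), and beside the earlier case of this change the result reads: the same change on two cores in this assay, a 1.2-fold higher number (0.07 log units; within the scatter) from compound 1 to compound 2 and a 1.5-fold lower number (0.17 log units; within the scatter) from compound 3 to compound 4, 1.7-fold (0.24 log units) apart, within the scatter of two such steps. On these two cores, then, the change carries over as a step that cannot be told from scatter, but two pairs cannot show that this would hold on other cores. The larger steps, a 13-fold lower number from compound 2 to compound 4 (1.11 log units; beyond the scatter) and an 11-fold lower number from compound 1 to compound 4 (1.04 log units; beyond the scatter), each replace a whole fluorinated phenyl group, so they do not show which fluoro counts.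

The compounds shown leave open how a different group in that same place, such as chloro or methoxy, would compare. They also leave open whether the aromatic ring needs any fluoro at all.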